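The compounds below may be only part of what the source reports. "The series", "measured", "known", "first", "only" and "open" are said of these compounds alone.

Compound 1 `CCCC(Nc1cncc(-c2ccc(O)c(OC)c2)n1)c1ccccc1` and compound 2 `CCCC(Nc1cncc(-c2ccc(O)c(OC)c2)n1)c1ccc(OC)cc1` share one core and differ only at one aromatic carbon of the phenyl ring on the side chain. In a functional assay on PC-3 cells (Homo sapiens) for cytotoxicity, read by MTT assay, with a stated time of 72 h (on this read-out higher numbers stand for weaker inhibition and lower numbers for stronger inhibition), compound 1 gives 160 nM, while compound 2 gives 3000 nM, the higher of the two numbers measured; the change a 19-fold higher number from compound 1 to compound 2 (1.27 log units; beyond the scatter) is large and beyond the scatter. Compound 3 `CCCC(Nc1cncc(-c2ccc(O)c(OC)c2)n1)c1ccc(Cl)cc1` keeps everything of compound 2 except that (chloro in place of methoxy on an aromatic carbon). Among the compounds with values here, no measured step swaps one group for another at this place; the only step that bears on it is the one from compound 1 to compound 2, which shows that a group at this carbon can weigh heavily. A chloro group there is expected to lower the number, though not back to where compound 1 stands, so the estimated step is a 3.3-fold lower number from compound 2 to compound 3 (0.52 log units; beyond the scatter). Compound 3 is therefore expected to give about 900 nM, with a range from 200 nM to 5000 nM.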

Compound 3, half-maximal inhibitory concentration: 20000 nM
Compound 3: middle estimate off by 22-fold (1.35 log units), on the low side, and the stated range ends below it.
By their numbers in this assay, from the lowest: compound 1; then compound 2; then compound 3.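

Swapping methoxy for chloro does not bring the number back towards that of the unsubstituted ring: in this assay the swap gives a 6.7-fold higher number from compound 2 to compound 3 (0.82 log units; beyond the scatter) and so marks weaker inhibition. Set against hydrogen, chloro gives a 130-fold higher number from compound 1 to compound 3 (2.10 log units; beyond the scatter) and is thus a far larger penalty than methoxy, so among these three compounds the identity of the group at this aromatic carbon matters, not only whether one is present. No measurement is available to explain the order of hydrogen, methoxy and chloro.

As far as these compounds go, it remains open whether any group at this carbon can match hydrogen, such as a fluoro, a methyl, a hydroxyl or an amine. The compounds shown also do not tell whether chloro would cost as much on another carbon of this ring.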